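Fluoro to chloro swap on two cores, macrophage assay

The compounds below may be only part of what the source reports. "The series", "measured", "known", "first", "only" and "open" are said of these compounds alone.

Measured so far:
- compound 1, `Cc1csc(NC(=O)Cn2cc(-c3ccc(Cl)cc3)nn2)n1`, gives 520 nM in a functional assay on BMDM cells (Mus musculus, strain C57BL/6) for inhibition, with a stated time of 2 days; a lower number here means a stronger inhibitor, a higher number a weaker inhibitor
- compound 2, `Cc1csc(NC(=O)Cn2cc(-c3ccc(F)cc3)nn2)n1`, gives 250 nM in this assay
- compound 3, `O=C(Cn1cc(-c2ccc(F)cc2)nn1)Nc1nc2ccccc2s1`, is reported only as a limit, > 30000 nM, in this assay

Compound 2 and compound 1 share one core and differ in a single place: chloro in place of fluoro on an aromatic carbon. In this assay this change gives a 2.1-fold higher number from compound 2 to compound 1 (0.32 log units; beyond the scatter), a loss of potency that is modest but beyond the usual scatter.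

Compound 3 carries a different core. The difference between the core of compound 2 and the core of compound 3 is not broken down here. In this assay compound 3 sits at the limit of > 30000 nM in this assay, at which 1 of the 3 values shown sits, so no number is available for it, only the statement that inhibition was not reached within the tested range.

Compound 4, `O=C(Cn1cc(-c2ccc(Cl)cc2)nn1)Nc1nc2ccccc2s1`, is not yet measured. It stands to compound 3 as compound 1 stands to compound 2: chloro in place of fluoro on an aromatic carbon. Among the compounds with values here, the two "place" descriptions match word for word, so this is the same change as the one measured between compound 2 and compound 1.

Expectation for compound 4 in this assay: the only measured instance of this change, from compound 2 to compound 1, weakened inhibition, and compound 3 already lies at the assay limit, so compound 4 is expected to stay at or beyond that limit, with an estimated step that the limit leaves unreadable from compound 3 to compound 4. The estimate for compound 4 is 60000 nM, with a likely range from 30000 nM to 300000 nM, and a high chance that only a limit is reported again.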

Compound 4, half-maximal inhibitory concentration: 130 nM
Compound 4: the middle estimate sits 460-fold (2.66 log units) above what was measured; the whole stated range lies above it.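

In this assay, chloro in place of fluoro on an aromatic carbon gives an at least 230-fold lower number from compound 3 to compound 4 (2.36 log units; beyond the scatter), a large gain in inhibition on the core of compound 3. The change therefore does not carry from one core to the other, either in direction or in size: the same change on two cores in this assay, a 2.1-fold higher number (0.32 log units; beyond the scatter) from compound 2 to compound 1 and an at least 230-fold lower number (2.36 log units; beyond the scatter) from compound 3 to compound 4, at least 480-fold (2.68 log units) apart, beyond the scatter of two such steps

As far as these compounds go, compound 3 is reported only as a limit, > 30000 nM, so the full size of this step stays unknown, and with a single pair on each core the data show that the outcome of the swap depends on the core, but not which part of the core decides it or how the swap would behave on a further core.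

Open, from the compounds shown here alone, is whether a bromo or a methoxy group on the same aromatic carbon would follow the chloro or the fluoro result on each core, and whether a plain phenyl ring would sit nearer to one or the other. Also open, going by these compounds, is whether an amine or a carboxylic acid at that place would be tolerated on either core, and whether the sharp dependence on the halogen seen with compound 3 and compound 4 extends to any other group.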